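This account rests on a few compounds, and the source may have more. Where it says the series, first, only, none or still open, it means among the compounds named here.

Compound 1 `Nc1ccccc1NC(=O)c1ccc(CNCc2nc(-c3ccc(C(F)(F)F)cc3)no2)cc1`: 6870 nM
Compound 2 `Nc1ccccc1NC(=O)c1ccc(CNCc2nc(-c3cccs3)no2)cc1`: 10400 nM

For the measured compounds named here, in a functional assay on MDA-MB-231 cells (Homo sapiens) for inhibition, read by MTT assay, with a stated time of 72 h (a higher number here means a weaker inhibitor, a lower number a stronger inhibitor), compound 2 gives 10400 nM and cannot be told apart from its only measured neighbour: a 1.5-fold higher number from compound 1 to compound 2 (0.18 log units; within the scatter). Compound 3 `O=C(NO)c1ccc(CNCc2nc(-c3cccs3)no2)cc1` keeps the thiophen-2-yl group of compound 2 but differs elsewhere: hydroxy in place of 2-aminophenyl on an amide-type nitrogen. In words, this is hydroxy in place of 2-aminophenyl on an amide-type nitrogen. Going by the values given here, the one measured step swapped thiophen-2-yl in place of 4-(trifluoromethyl)phenyl on an aromatic carbon, a different place, so it offers no direct guide here. Among the compounds with values here, no measured step covers this change, so the forecast is a loose judgement. The change is a large one, and compound 2 at 10400 nM leaves much room downward, so a lower number is expected. The expected step is a 4.2-fold lower number from compound 2 to compound 3 (0.62 log units; beyond the scatter). For compound 3 the estimate is 2500 nM, with an expected range of 400 nM to 12000 nM.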

Compound 3, half-maximal inhibitory concentration: 23900 nM
For compound 3 the middle estimate is 9.6-fold (0.98 log units) below the measured one; measured number above the stated range.
By their numbers in this assay, from the lowest: compounds 1 and 2 (each within the scatter of the next); then compound 3.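

In this assay, hydroxy in place of 2-aminophenyl on the amide-type nitrogen gives a 2.3-fold higher number from compound 2 to compound 3 (0.36 log units; beyond the scatter), a modest change, but the first in this set to lie beyond the scatter. This position therefore affects the read-out in a way the earlier swap on an aromatic carbon did not show, and here the much smaller group, which has no ring, gives the weaker inhibitor even though the two groups have matching hydrogen-bond donor and acceptor counts. Nothing available explains why this change weakens inhibition.

The compounds shown leave open how a plain phenyl group or a 2-hydroxyphenyl group on that nitrogen would compare. They also leave open whether hydroxy has the same effect when 4-(trifluoromethyl)phenyl replaces thiophen-2-yl.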